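One Fluorine Less: Expected Effect on Receptor Binding

A few compounds are considered here, and "the series" means these few. Any claim that something is new, unique, unknown or untested is made for them only; others in the source may bear on it.

compound 1 `CCC(/C=C1\OC(=O)NC1=O)(CC)c1ccc(-c2ccc3cc(F)cc(F)c3c2)[nH]c1=O`: 28 nM
compound 2 `CC(C)(/C=C1\OC(=O)NC1=O)c1ccc(-c2ccc3cccc(F)c3c2)[nH]c1=O`: 38 nM
compound 3 `Cc1cc(C(/C=C2\OC(=O)NC2=O)C(C)C)c(=O)[nH]c1-c1ccc2cccc(F)c2c1`: 23 nM

In an assay on membranes from Chem-1 cells for displacement of a labelled ligand from prostaglandin E2 receptor EP3 subtype (Homo sapiens), read by scintillation counting, with a stated time of 2 h (a lower number here means a stronger inhibitor, a higher number a weaker inhibitor), the three numbers fall within the usual scatter of one another, so compound 1 cannot be set above or below compound 2 or compound 3 on this evidence. Compound 4 `CCC(/C=C1\OC(=O)NC1=O)(CC)c1ccc(-c2ccc3cccc(F)c3c2)[nH]c1=O` has not been measured. It differs from compound 1 in one place: hydrogen in place of fluoro on an aromatic carbon. Among the compounds with values here, no measured pair isolates this change, so the expectation rests on the other compounds: compound 2 carries a single fluoro on the same fused ring system and gives 38 nM, and compound 3 gives 23 nM. The step of a 1.3-fold higher number from compound 1 to compound 4 (0.10 log units; within the scatter) is therefore expected to stay within the scatter. Compound 4 is estimated at 35 nM, with a range from 15 nM to 80 nM.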

Compound 4, inhibition constant: 13 nM
Estimate against measurement, compound 4: 2.7-fold (0.43 log units) above; the whole stated range lies above it.
By their numbers in this assay, from the lowest: compounds 4, 3, 1 and 2 (each within the scatter of the next, the first and the last beyond it).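

In this assay, within the data shown here, hydrogen in place of fluoro on this aromatic carbon gives a 2.2-fold lower number from compound 1 to compound 4 (0.33 log units; beyond the scatter), the first comparison in this set that isolates a single change. The step is modest, but it shows that this position does respond and that binding here does not depend on this fluoro. The data offer no explanation for the step. Going by these compounds, whether a chloro or a methoxy group at this carbon would do better or worse remains open. So does the effect of replacing the other fluoro, which compound 4 keeps, with hydrogen.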